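Acylating the amino group of compound 2

The source may hold more compounds than are shown below. What is called first, only, known or untested is meant among the compounds shown, and "the series" means these compounds.

In a functional assay on K562 cells (Homo sapiens) for inhibition, read by MTT assay, with a stated time of 48 h (a higher number here means a weaker inhibitor, a lower number a stronger inhibitor), compound 1 (`O=C(Nc1nc2ccc(-c3cn([C@@H]4CN[C@H](C(=O)Nc5ccc(Br)cc5)C4)nn3)nc2s1)C1CC1`) gives 8160 nM and compound 2 (`Nc1nc2ccc(-c3cn([C@@H]4CN[C@H](C(=O)Nc5ccc(F)c(F)c5)C4)nn3)nc2s1`) gives 33200 nM as the higher of the two numbers, with a gap beyond the scatter. These two compounds differ in more than one place, so that gap is not tied to a single change. Compound 3 (`O=C(Nc1nc2ccc(-c3cn([C@@H]4CN[C@H](C(=O)Nc5ccc(F)c(F)c5)C4)nn3)nc2s1)C1CC1`) differs from compound 2 in one place, with cyclopropylcarbonyl in place of hydrogen on a nitrogen on an aromatic ring. Among the compounds with values here, compound 1 carries the same cyclopropylcarbonyl at 8160 nM and so a moderate step to a lower number is expected in this assay even though no measured pair isolates this change. The estimated move is a 2.8-fold lower number from compound 2 to compound 3 (0.44 log units; beyond the scatter) on this limited evidence. Compound 3 is estimated at 12000 nM (expected range 5000 nM to 30000 nM).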

Compound 3, half-maximal inhibitory concentration: 40700 nM
Beside the measured number, compound 3's estimate is 3.4-fold (0.53 log units) below it, outside the stated range (above it).
By their numbers in this assay, from the lowest: compound 1; then compounds 2 and 3 (each within the scatter of the next).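

In this assay, cyclopropylcarbonyl in place of hydrogen on the nitrogen on the aromatic ring gives a 1.2-fold higher number from compound 2 to compound 3 (0.09 log units; within the scatter), so on the 3,4-difluorophenyl amide this acylation produces no readable step. Within the data shown here, with cyclopropylcarbonyl held in place, 3,4-difluorophenyl in place of 4-bromophenyl on the amide-type nitrogen gives a 5.0-fold higher number from compound 1 to compound 3 (0.70 log units; beyond the scatter), the only step of the two that lies beyond the scatter. No data on why either step has its size are available here.

It remains open whether amino to (cyclopropylcarbonyl)amino reads the same on the 4-bromophenyl amide, where no such pair is shown. Also open, on these data alone, is whether an acetyl or a dimethylaminoacetyl group on that nitrogen would read differently from cyclopropylcarbonyl in this assay.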